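A few compounds are considered here, and "the series" means these few. Any claim that something is new, unique, unknown or untested is made for them only; others in the source may bear on it.

Compound 1 `CCCCOS(=O)(=O)/C=C/c1ccc(OCc2ccccc2)cc1OCCc1nc(-c2ccccc2)oc1C` gives > 100000 nM in an ADME assay on COS-7 cells (Chlorocebus aethiops) for cytotoxicity, read by MTT assay, with a stated time of 48 h (a higher number here means a weaker inhibitor, a lower number a stronger inhibitor), which is a limit of the assay and not a number.
Compound 2 `CCOS(=O)(=O)/C=C/Cc1cc2ccc(OCCc3nc(-c4ccccc4)oc3C)cc2o1` gives > 100000 nM in this assay, again a limit of the assay.
Compound 3 `CCCCOS(=O)(=O)/C=C/c1ccc(OCCc2nc(-c3ccccc3)oc2C)cc1` gives > 100000 nM in this assay, also a limit of the assay.

On the numbers shown, compound 3 therefore does not stand at a measured point at all: its result is only a limit, and the same holds for the two other compounds, as the limit of > 100000 nM in this assay, at which 3 of the 3 values shown sit, shows. Going by the values given here, no step between two measured compounds can be drawn from these three results.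

The next compound is compound 4 `CCOS(=O)(=O)/C=C/c1ccc(OCCc2nc(-c3ccccc3)oc2C)cc1`. The change from compound 3 is hydrogen in place of ethyl on a saturated chain carbon, two bonds along the chain from an oxygen on an unsaturated carbon, a small trimming of a chain at its end.

With every known result sitting at the same limit, there is no ground to expect that this small change would move compound 4 out of that region. The step of a number no higher from compound 3 to compound 4 (the limit leaves the size open) is expected to be none beyond the scatter. Compound 4 is estimated at 100000 nM in this assay, within 50000 nM to 200000 nM, most likely reported once more as a limit rather than a number.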

Compound 4, half-maximal inhibitory concentration: 84100 nM
Estimate against measurement, compound 4: 1.2-fold (0.08 log units) above; the range from low to high includes it.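

Replacing butoxy with ethoxy yields a measured number in this assay, where compound 4 gives 84100 nM. From the compounds shown here alone, the comparison reads as an at least 1.1-fold lower number from compound 3 to compound 4 (0.07 log units; that floor lies within the scatter), and the true size of the step stays open, since one side of it is only a limit of the assay. Compound 4 is therefore the only compound shown with a measured number, and it shows that a value can be read in this series, while the others remain at a limit: the limit of > 100000 nM in this assay, at which 3 of the 4 values shown sit.

Going by these compounds, it remains open what a methoxy group, a longer chain such as hexyloxy, or a chain ending in an amine would give in this place. On these data alone, it is also open whether the same trimming would have any effect on the core of compound 1.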